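Fluoro in Place of Carboxy: One Change, Two Rings

This account rests on a few compounds, and the source may have more. Where it says the series, first, only, none or still open, it means among the compounds named here.

Compound 1 `CCN(CC)c1nc(Nc2ccc(C(=O)O)cc2)nc(OC(C(F)(F)F)C(F)(F)F)n1`: 900 nM
Compound 2 `CCN(CC)c1nc(Nc2ccc(F)cc2)nc(OC(C(F)(F)F)C(F)(F)F)n1`: 700 nM
Compound 3 `CCN(CC)c1nc(Nc2cccc(C(=O)O)c2)nc(OCC(F)(F)C(F)F)n1`: 500 nM

In an assay on cells for activation of Cystic fibrosis transmembrane conductance regulator (Homo sapiens), read by fluorescence, with stated times of 10 min and 12 s (on this read-out lower numbers stand for an effect already at smaller amounts and higher numbers for an effect only at larger amounts of compound), compound 1 gives 900 nM, compound 2 gives 700 nM, and compound 3 gives 500 nM. The change fluoro in place of carboxy on an aromatic carbon produced a 1.3-fold lower number from compound 1 to compound 2 (0.11 log units; within the scatter). Compound 4 `CCN(CC)c1nc(Nc2cccc(F)c2)nc(OCC(F)(F)C(F)F)n1` carries the same kind of change relative to compound 3, namely (fluoro in place of carboxy on an aromatic carbon); the surroundings differ, the earlier change sitting para to a large group and this one meta to a large group. How the core of compound 3 differs from the core of compound 1 is not broken down here. Compound 4 is expected to show a 1.1-fold lower number from compound 3 to compound 4 (0.05 log units; within the scatter) in this assay. That expectation rests on the earlier step of a 1.3-fold lower number from compound 1 to compound 2 (0.11 log units; within the scatter), which stayed within the scatter. Compound 4 is therefore estimated at 450 nM, with a range from 200 nM to 1200 nM.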

Compound 4, half-maximal effective concentration: 1600 nM
Estimate against measurement, compound 4: 3.6-fold (0.55 log units) below; the measured number lies above the stated range.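

On the core of compound 3, fluoro in place of carboxy gives a 3.2-fold higher number from compound 3 to compound 4 (0.51 log units; beyond the scatter) in this assay. The size of the change on one core therefore did not carry over to the other, and the two steps differ: the same change on two cores in this assay, a 1.3-fold lower number (0.11 log units; within the scatter) from compound 1 to compound 2 and a 3.2-fold higher number (0.51 log units; beyond the scatter) from compound 3 to compound 4, 4.1-fold (0.61 log units) apart, beyond the scatter of two such steps. This does not show whether the place on the aromatic ring or some other difference between the two pairs accounts for the gap, as the pairs differ in more than one respect and only two are shown.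

The compounds shown leave open whether 3-carboxyphenyl to 3-fluorophenyl would give a similar step on the core of compound 1. They also leave open how an amide or an amine in place of carboxy would read on either core.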